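This account rests on a few compounds, and the source may have more. Where it says the series, first, only, none or still open, it means among the compounds named here.

Compound 1, `CCCCCCCCCCCCCCCC(=O)NCC(=O)N[C@@H]1[C@@H](O)[C@H](O)[C@@H](Nc2ncnc3[nH]cnc23)O[C@H]1CO`, gives 2.5 uM in a functional assay on L1210 cells (Mus musculus) for inhibition, read by thymidine incorporation, with a stated time of 3 h; on this read-out higher numbers stand for an effect only at larger amounts of compound and lower numbers for an effect already at smaller amounts. Compound 2, `CC(C)CCCCCCCCCCCCC(=O)NCC(=O)N[C@@H]1[C@@H](O)[C@H](O)[C@@H](Nc2ncnc3[nH]cnc23)O[C@H]1C`, gives 1.8 uM in this assay; of the two numbers on record it is the lower, yet compound 1 sits within the scatter of it, so the two cannot be told apart. Compound 3, `CC(C)CCCCCCCCCCCCC(=O)N[C@@H]1[C@@H](O)[C@H](O)[C@@H](Nc2ncnc3[nH]cnc23)O[C@H]1C`, reaches only a limit of the assay, > 1000 uM, in this assay. That is the limit of > 1000 uM in this assay, at which 1 of the 3 values shown sits, a boundary and not a number.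

Compound 4, `CCCCCCCCCCCC(=O)NCC(=O)N[C@@H]1[C@@H](O)[C@H](O)[C@@H](Nc2ncnc3[nH]cnc23)O[C@H]1C`, has not yet been measured. It differs from compound 2 by hydrogen in place of isobutyl on a saturated chain carbon, ten or more bonds along the chain from a carbonyl carbon. Going by the values given here, no measured pair shows this change alone, so its size is not fixed by the data. Since the chain is cut far from the carbonyl while the rest of compound 2 is kept, a moderate move toward a higher number is expected, with the step of a 3.9-fold higher number from compound 2 to compound 4 (0.59 log units; beyond the scatter) estimated to lie just beyond the scatter. Compound 4 is therefore expected to give about 7 uM in this assay, within a range from 1.5 uM to 40 uM.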

Compound 4, concentration for half-maximal effect: 29 uM
Compound 4: the middle estimate sits 4.1-fold (0.62 log units) below what was measured; the measured number falls inside the stated range.
By their numbers in this assay, from the lowest: compounds 2 and 1 (each within the scatter of the next); then compound 4. At a limit, above all of these: compound 3.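

In this assay, hydrogen in place of isobutyl gives a 16-fold higher number from compound 2 to compound 4 (1.21 log units; beyond the scatter) as a large step, with the rest of compound 2 kept. Going by these compounds alone, this is the first step that can be read at a single place, and it shows that the outer end of the chain is not a silent part of the structure. Nothing shown here gives a cause for this step.

The compounds shown leave open whether the number keeps climbing as the chain is cut further, or whether a longer chain would bring it down. They also leave open how an amine or a carboxylic acid at the end of the chain would read in this assay.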